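Carboxylic headgroups and cytotoxicity across the series

This account rests on a few compounds, and the source may have more. Where it says the series, first, only, none or still open, it means among the compounds named here.

The series shares one core, carried in compound 1 `COc1ccc(/C=C\c2cc(OC)c(OC)c(OC)c2)cc1OCc1ccc(CN[C@H](C(=O)O)[C@H](C)O)cc1`, compound 2 `COc1ccc(/C=C\c2cc(OC)c(OC)c(OC)c2)cc1OCc1ccc(CN2C[C@H](O)C[C@@H]2C(=O)O)cc1` and compound 3 `COc1ccc(/C=C\c2cc(OC)c(OC)c(OC)c2)cc1OCc1ccc(CN2CCCC[C@H]2C(=O)O)cc1`, and the three differ only in the group on a saturated chain carbon bound to an aromatic carbon. In an ADME assay on HEK293 cells (Homo sapiens) for cytotoxicity, read by CCK-8 assay, with a stated time of 48 h (a lower number here means a stronger inhibitor, a higher number a weaker inhibitor), compound 1 gives > 50000 nM, which is a limit of the assay and not a number. Compound 2 in this assay likewise returns a limit, > 50000 nM. Compound 3 also returns a limit, > 50000 nM. Among the compounds with values here, all three values thus sit at the limit of > 50000 nM in this assay, at which 3 of the 3 values shown sit, so none of the measured steps can be read: a step that the two limits leave unreadable from compound 1 to compound 2, a step that the two limits leave unreadable from compound 1 to compound 3 and a step that the two limits leave unreadable from compound 2 to compound 3.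

Compound 4 `COc1ccc(/C=C\c2cc(OC)c(OC)c(OC)c2)cc1OCc1ccc(CN2CC[C@@H](C(=O)O)C2)cc1` is not yet measured. Its change from compound 2 is 3-carboxypyrrolidin-1-yl in place of 2-carboxy-4-hydroxypyrrolidin-1-yl on a saturated chain carbon bound to an aromatic carbon. Within the data shown here, the steps that bear on it, from compound 1 to compound 2, from compound 1 to compound 3 and from compound 2 to compound 3, all run between limits, so no size and no direction can be taken from them in this assay. On that basis no step beyond the scatter is expected, and compound 4 is expected to remain at the limit, with a step that the limit leaves unreadable from compound 2 to compound 4 as the estimated step. The estimate for compound 4 in this assay is 60000 nM, in the range 30000 nM to 200000 nM.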

Compound 4, half-maximal inhibitory concentration: 27000 nM
For compound 4 the middle estimate is 2.2-fold (0.35 log units) above the measured one; the measured number lies below the stated range.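

In this assay, within the data shown here, compound 4 is the first compound to return a number and not a limit, so a change at this place, on a saturated chain carbon bound to an aromatic carbon, can now be given a direction and a minimum size. Going to 3-carboxypyrrolidin-1-yl gives an at least 1.8-fold lower number from compound 2 to compound 4 (0.26 log units; that floor lies within the scatter), an at least 1.8-fold lower number from compound 3 to compound 4 (0.26 log units; that floor lies within the scatter) and an at least 1.8-fold lower number from compound 1 to compound 4 (0.26 log units; that floor lies within the scatter). Each step is only a floor, and its true size stays unknown, because the other end of each is a limit: the limit of > 50000 nM in this assay, at which 3 of the 4 values shown sit.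

The step from 2-carboxy-4-hydroxypyrrolidin-1-yl to 3-carboxypyrrolidin-1-yl changes the place of the carboxylic acid and removes the hydroxy group in one move, so the shift in this assay cannot be assigned to either change alone. A 2-carboxypyrrolidin-1-yl group would separate the two changes, and a 3-carboxypiperidin-1-yl group would show whether the same reading holds with the six-membered ring of compound 3.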